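Swapping the ring on the core nitrogen of compound 1

This account rests on a few compounds, and the source may have more. Where it says the series, first, only, none or still open, it means among the compounds named here.

Of the compounds shown here, three have been measured in a functional assay on HCC827 cells (Homo sapiens) for antiproliferative activity, read by MTT assay, with a stated time of 72 h; a lower number here means a stronger inhibitor, a higher number a weaker inhibitor. Compound 1 `CN1CCN(c2ccc(Nc3ncc4nc([S+]([O-])c5ccccc5)n([C@H]5CC[C@H](O)CC5)c4n3)cc2)CC1` gives 268 nM, the lowest of the three numbers. Compound 3 `CN(C)CCN(C)c1ccc(Nc2ncc3nc(Sc4ccccc4)n(C4CCOCC4)c3n2)cc1` gives 499 nM, which lies within the scatter of compound 1. Compound 2 `CN1CCN(c2ccc(Nc3ncc4nc(SCc5cccnc5)n(C5CC5)c4n3)cc2)CC1` gives 8830 nM, a gap from compound 1 that is beyond the scatter. Compound 4 `CN1CCN(c2ccc(Nc3ncc4nc([S+]([O-])c5ccccc5)n(C5CCOCC5)c4n3)cc2)CC1` is not yet measured. It differs from compound 1 in one place: oxan-4-yl in place of 4-hydroxycyclohexyl on an aromatic nitrogen. Among the measured compounds shown here, no measured pair shows this single change on its own. Because compound 3, which also carries oxan-4-yl on that nitrogen, gives 499 nM, a small step is expected, if any, toward a higher number. The expected step in this assay is a 1.3-fold higher number from compound 1 to compound 4 (0.12 log units; within the scatter). Compound 4 is estimated at 350 nM, with a range from 150 nM to 900 nM.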

Compound 4, half-maximal inhibitory concentration: 411 nM
Beside the measured number, compound 4's estimate is 1.2-fold (0.07 log units) below it; low and high end bracket the measured number.
By their numbers in this assay, from the lowest: compounds 1, 4 and 3 (each within the scatter of the next); then compound 2.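

Among the compounds shown here, this is the first pair that isolates the group on this aromatic nitrogen. In this assay, oxan-4-yl in place of 4-hydroxycyclohexyl gives a 1.5-fold higher number from compound 1 to compound 4 (0.19 log units; within the scatter), so removing the hydrogen-bond donor and the defined stereocentres leaves the number within the scatter. No measurement here explains why this swap makes so little difference.

Still open, on these data alone, is how an amine-bearing ring such as piperidin-4-yl or an open alkyl chain would read on this nitrogen. A plain cyclohexyl ring, with no oxygen at all, also remains an open comparison.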